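From Hydroxyamino to Methylsulfanyl: Little Change Expected

This account rests on a few compounds, and the source may have more. Where it says the series, first, only, none or still open, it means among the compounds named here.

In a functional assay on NCI-H460 cells (Homo sapiens) for inhibition, read by MTT assay, with a stated time of 72 h (on this read-out lower numbers stand for stronger inhibition and higher numbers for weaker inhibition), compound 2 `O=c1nc(NO)cc[nH]1` gives > 100000 nM, which is a limit of the assay rather than a number. Compound 1 `N[C@H](CSCC(=O)Nc1c[nH]c(=O)[nH]c1=O)C(=O)O` likewise reaches only the limit of > 100000 nM. Compound 3 `NCC(=O)Nc1c[nH]c(=O)[nH]c1=O` too stops at the limit of > 100000 nM. Compound 2 thus stands where every measured compound stands, at the limit of > 100000 nM in this assay, at which 3 of the 3 values shown sit. Compound 4 `CSc1cc[nH]c(=O)n1` differs from compound 2 by methylsulfanyl in place of hydroxyamino on an aromatic carbon. Within the data shown here, no step between measured compounds is known here, and none of the three gives a number that could anchor a change. The expected step in this assay is a step that the limit leaves unreadable from compound 2 to compound 4, that is, no shift beyond the usual scatter. Compound 4 is therefore estimated at 150000 nM, between 30000 nM and 500000 nM, most likely reported again only as a limit.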

Compound 4, half-maximal inhibitory concentration: > 100000 nM
Compound 4: only a limit was reported (the forecaster's own chance of this, stated with the estimate: 85%); the middle value is on the limit's open side.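

Among these compounds, compound 2 and compound 4 both end at a limit rather than a number, so no step from one to the other can be read. Left open is whether methylsulfanyl in place of hydroxyamino changes inhibition at all, since all the compounds shown share one ceiling: the limit of > 100000 nM in this assay, at which 4 of the 4 values shown sit.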